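Swapping the Aryl Group on Compound 3

The source may report more compounds than this note shows. Statements on the series, on what has been measured and on what is new or still open speak of the compounds shown alone.

Three compounds have been measured in a functional assay on Caco-2 cells (Homo sapiens) for inhibition, read by MTT assay, with a stated time of 48 h, tested at 10 uM; a lower number here means less inhibition of growth, a higher number more inhibition of growth at the concentration tested:
Compound 1, `Cc1cc(=O)c2c(O)c(CN3CCN(C(=O)OC(C)(C)C)CC3)c(O)c([C@H]3CCN(C)C[C@H]3O)c2o1`, gives 21%.
Compound 2, `CCOC(=O)N1CCN(Cc2c(O)c([C@H]3CCN(C)C[C@H]3O)c3oc(C)cc(=O)c3c2O)CC1`, gives 18%.
Compound 3, `Cc1oc2c([C@H]3CCN(C)C[C@H]3O)c(O)cc(O)c2c(=O)c1C(O)c1ccc([N+](=O)[O-])cc1`, gives 5%.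

Compound 3 stands lowest of the three; compound 2 and compound 1 both lie beyond the scatter above it. Compound 4, `CCOc1ccc(Br)c(C(O)c2c(C)oc3c([C@H]4CCN(C)C[C@H]4O)c(O)cc(O)c3c2=O)c1`, differs from compound 3 by 2-bromo-5-ethoxyphenyl in place of 4-nitrophenyl on a saturated chain carbon bound to an aromatic carbon and an oxygen on a saturated carbon. Within the data shown here, the only measured step, a number 3 percentage points lower from compound 1 to compound 2 (within the scatter), concerns a different part of the shared core and lies within the scatter, so it offers no guide to this exchange. Among the measured compounds shown here, with no comparable step to lean on, the expected change from compound 3 to compound 4 is none beyond the scatter: a number 5 percentage points higher from compound 3 to compound 4 (within the scatter). Compound 4 is therefore estimated at 10%, with a likely range from 0% to 28%.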

Compound 4, percent growth inhibition at one concentration: 5%
The estimate for compound 4 lay 5 percentage points above the measured number; the range from low to high includes it.
By their numbers in this assay, from the lowest: compounds 3 and 4 (each within the scatter of the next); then compounds 2 and 1 (each within the scatter of the next).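

Putting 2-bromo-5-ethoxyphenyl in place of 4-nitrophenyl on this saturated chain carbon gives no change at the digits printed from compound 3 to compound 4 (within the scatter) in this assay. At this position, then, two differently substituted aryl groups cannot be told apart by this read-out. No other data bear on what lies behind this result.

Whether any group at this carbon can raise the number remains open, as only these two aryl groups are shown there. A 4-aminophenyl group, or a saturated cyclohexyl group in place of the aromatic ring, could still read differently.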